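From compound 3 to compound 4 at the limit

A few compounds are considered here, and "the series" means these few. Any claim that something is new, unique, unknown or untested is made for them only; others in the source may bear on it.

Measured in a functional assay on cells (leukaemia cell line, Homo sapiens) for inhibition, read by sulforhodamine B assay, with a stated time of 48 h; a higher number here means that more compound is tolerated, a lower number that less compound is tolerated:
Compound 1 (`O=S(=O)(Nc1ccccc1Cl)c1ccc(-c2cnc(C3CC3)o2)cc1`) gives > 100000 nM (a limit)
Compound 2 (`Cc1cc(NS(=O)(=O)c2ccc(-c3cnc(C4CC4)o3)cc2)ccc1Cl`) gives > 100000 nM (a limit)
Compound 3 (`COc1cc(NS(=O)(=O)c2ccc(-c3cnc(C4CC4)o3)cc2)ccc1F`) gives > 100000 nM (a limit)

Compound 3 stands with a reading of > 100000 nM (a limit of the assay and not a number). Its standing among the measured compounds comes down to this: the limit of > 100000 nM in this assay, at which 3 of the 3 values shown sit (so no rank can be given).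

The step to compound 4 (`Cc1cc(F)cc(NS(=O)(=O)c2ccc(-c3cnc(C4CC4)o3)cc2)c1`) puts 3-fluoro-5-methylphenyl in place of 4-fluoro-3-methoxyphenyl on a sulfonamide nitrogen and leaves the shared core as it is.

Among the compounds with values here, three measured steps bear on this change, as each alters the group at that same place. They are a step that the two limits leave unreadable from compound 1 to compound 2 and a step that the two limits leave unreadable from compound 1 to compound 3 and a step that the two limits leave unreadable from compound 2 to compound 3 (none has a size that can be read). They therefore offer no size to carry over, so no readable step and no direction can be expected in this assay for this change. The expected outcome is a number no higher from compound 3 to compound 4 (the limit leaves the size open) (an estimate only).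

Within the data shown here, compound 4 is expected to be reported as a limit as well, because the limit of > 100000 nM in this assay, at which 3 of the 3 values shown sit (the only precedent available). Compound 4 is estimated at 100000 nM (expected range 50000 nM to 200000 nM).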

Compound 4, concentration lethal to 50% of the cells: 78100 nM
The estimate for compound 4 lay 1.3-fold (0.11 log units) above the measured number; measured number inside the range.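

In this assay compound 4, with 3-fluoro-5-methylphenyl on the sulfonamide nitrogen, is the only compound shown that gives a number and not a limit: the limit of > 100000 nM in this assay, at which 3 of the 4 values shown sit. Within the data shown here, this gives the first readable steps at this position, though each rests on a limit and gives only a floor: an at least 1.2-fold lower number from compound 3 to compound 4 (0.10 log units; that floor lies within the scatter), an at least 1.2-fold lower number from compound 2 to compound 4 (0.10 log units; that floor lies within the scatter) and an at least 1.2-fold lower number from compound 1 to compound 4 (0.10 log units; that floor lies within the scatter). These floors show that a change at this position can bring a reading inside the range of the assay, but they do not show a difference beyond the scatter, and the steps among compound 1, compound 2 and compound 3 cannot be read.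

Going by these compounds, what the fluorine and the methyl of the 3-fluoro-5-methylphenyl each contribute stays open, as does the true size of the steps to compound 4. Also open, on these data alone, is how an amine or a carboxylic acid on this phenyl ring would read in this assay, and whether any group at this position would give a number clearly beyond the scatter of that of compound 4.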